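Ethynyl in Place of Methylsulfonyloxy: an Expected Recovery

A few compounds are considered here, and "the series" means these few. Any claim that something is new, unique, unknown or untested is made for them only; others in the source may bear on it.

Compound 1 `COc1cccc(C#Cc2csc(C)n2)c1`: 49 nM
Compound 2 `Cc1nc(C#Cc2cncc(C#CCO)c2)cs1`: 68.6 nM
Compound 3 `Cc1nc(C#Cc2cccnc2OS(C)(=O)=O)cs1`: > 10000 nM

In a functional assay on CHO cells for agonist activity at metabotropic glutamate receptor 5 (Homo sapiens), read by inositol phosphate accumulation (a higher number here means a weaker inhibitor, a lower number a stronger inhibitor), compound 1 gives 49 nM and compound 2 gives 68.6 nM. For compound 3 the assay returns only a limit, > 10000 nM, not a number. Compound 3 therefore sits at the limit of > 10000 nM in this assay, at which 1 of the 3 values shown sits, while compounds 1 and 2 sit well inside the measurable range. Compound 4 `C#Cc1ncccc1C#Cc1csc(C)n1` has not yet been measured. The change from compound 3 is ethynyl in place of (methylsulfonyl)oxy on an aromatic carbon. Going by the values given here, no step between measured compounds has been recorded, so the direction of this one can only be guessed from the values above. A large step toward stronger inhibition is expected, an at least 66-fold lower number from compound 3 to compound 4 (1.82 log units; beyond the scatter). For compound 4 the estimate is 150 nM, expected to lie between 20 nM and 2000 nM.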

Compound 4, half-maximal inhibitory concentration: 192 nM
For compound 4 the middle estimate is 1.3-fold (0.11 log units) below the measured one, and the stated range covers the measured number.
By their numbers in this assay, from the lowest: compounds 1 and 2 (each within the scatter of the next); then compound 4. At a limit, above all of these: compound 3.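

On an aromatic carbon next to the ring nitrogen, ethynyl in place of (methylsulfonyl)oxy brings an at least 52-fold lower number from compound 3 to compound 4 (1.71 log units; beyond the scatter) in this assay. This carbon can therefore carry a substituent and still give a measurable number, and the choice of group there matters greatly. Compound 3 stands only at a limit, so the full size of this step stays unknown: the limit of > 10000 nM in this assay, at which 1 of the 4 values shown sits.

Still open, on these data alone, is whether the recovery comes from ethynyl itself or simply from losing (methylsulfonyl)oxy. A plain hydrogen, a methyl or an amine on this carbon would separate these two readings.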